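The source may report more compounds than this note shows. Statements on the series, on what has been measured and on what is new or still open speak of the compounds shown alone.

Measured compounds, with their half-maximal inhibitory concentrations in a functional assay on KYSE-450 cells (Homo sapiens) for inhibition, read by MTT assay, with a stated time of 48 h; a lower number here means a stronger inhibitor, a higher number a weaker inhibitor:

Compound 1 `CCC(=O)N(Cc1ccc(OC)c(O)c1)c1cc(OC)c(OC)c(OC)c1` gives 98 nM.
Compound 2 `COc1ccc(CN(C(=O)C2CC2)c2cc(OC)c(OC)c(OC)c2)cc1O` gives 80 nM.
Compound 3 `C#CC(=O)N(Cc1ccc(OC)c(O)c1)c1cc(OC)c(OC)c(OC)c1` gives 570 nM.

Compound 3 stands at the weakest end of these three: the step of a 5.8-fold higher number from compound 1 to compound 3 (0.76 log units; beyond the scatter) and the step of a 7.1-fold higher number from compound 2 to compound 3 (0.85 log units; beyond the scatter) both lie beyond the scatter, while the step of a 1.2-fold lower number from compound 1 to compound 2 (0.09 log units; within the scatter) does not. Compound 4 `COc1ccc(CN(C(=O)C[Se]C#N)c2cc(OC)c(OC)c(OC)c2)cc1O` differs from compound 3 in one place: a group of 4 heavy atoms (2 carbon, 1 nitrogen, 1 selenium; no ring) in place of a group of 2 heavy atoms (2 carbon; no ring), on a carbonyl carbon. Among the measured compounds shown here, the only measured steps that touch the ethynyl group are those leading to compound 3, and each of them made the number higher. Read in reverse, removing the ethynyl group could be expected to lower the number again, but no measured compound carries a group resembling the one that enters here, so the size of the step is uncertain. For compound 4 in this assay a step of a 3.8-fold lower number from compound 3 to compound 4 (0.58 log units; beyond the scatter) is expected, towards a lower number. The estimate for compound 4 is therefore 150 nM, with a range from 40 nM to 600 nM.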

Compound 4, half-maximal inhibitory concentration: 280 nM
The estimate for compound 4 lay 1.9-fold (0.27 log units) below the measured number, and the stated range covers the measured number.
By their numbers in this assay, from the lowest: compounds 2 and 1 (each within the scatter of the next); then compound 4; then compound 3.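

Placing the selenium-bearing group of 4 heavy atoms on this carbonyl carbon instead of ethynyl gives a 2.0-fold lower number from compound 3 to compound 4 (0.31 log units; beyond the scatter) in this assay, so this position does not hold only the groups seen earlier, and a triple bond here does not fix the number at a single level. The gain does not reach the earlier level, with a 2.9-fold higher number from compound 1 to compound 4 (0.46 log units; beyond the scatter) and a 3.5-fold higher number from compound 2 to compound 4 (0.54 log units; beyond the scatter) in this assay, so among these four compounds the two carrying a triple bond both stand above the two without one. Nothing available on these compounds explains these differences.

Whether the selenium or the nitrile accounts for the step stays open. From the compounds shown here alone, how a sulfur atom in place of the selenium, or a longer chain or an amine on this carbonyl carbon, would move the number also remains unknown.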